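Sulfonyl for carbonyl on the aromatic oxygen: compound 4

This account rests on a few compounds, and the source may have more. Where it says the series, first, only, none or still open, it means among the compounds named here.

Within the data shown here, in an ADME assay on L02 cells (Homo sapiens) for cytotoxicity, read by MTT assay (on this read-out lower numbers stand for stronger inhibition and higher numbers for weaker inhibition), compound 3 (`COc1ccc(/C=C/C(=O)c2ccc(OC)c3c2OC(C)(C)C=C3)cc1OC(=O)c1ccc(Br)cc1`) gives 8400 nM, the only actual number in this small set. Compound 1 (`C#CCOc1cc(/C=C/C(=O)c2ccc(OC)c3c2OC(C)(C)C=C3)ccc1OC`) reads > 10000 nM, which is a limit of the assay. Compound 2 (`COc1cccc(C(=O)Oc2cc(/C=C/C(=O)c3ccc(OC)c4c3OC(C)(C)C=C4)ccc2OC)c1`) reads > 10000 nM, also a limit.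

Compound 4 (`COc1ccc(/C=C/C(=O)c2ccc(OC)c3c2OC(C)(C)C=C3)cc1OS(=O)(=O)c1ccc(C)cc1`) has (4-methylphenyl)sulfonyl in place of (4-bromophenyl)carbonyl on an oxygen on an aromatic ring.

The relevant measured steps change the group on this same oxygen. They are an at least 1.1-fold lower number from compound 1 to compound 3 (0.07 log units; that floor lies within the scatter) and an at least 1.1-fold lower number from compound 2 to compound 3 (0.07 log units; that floor lies within the scatter), and both floors lie within the scatter. The third, a step that the two limits leave unreadable from compound 1 to compound 2, cannot be sized. Among the measured compounds shown here, no sulfonyl compound has been measured, so the swap has no direct precedent here. With no measured step beyond the scatter to build on, no change beyond the scatter is expected in this assay, in either direction. The expected move is a 1.1-fold higher number from compound 3 to compound 4 (0.03 log units; within the scatter). For compound 4 the estimated value is 9000 nM, with an expected range of 5000 nM to 16000 nM.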

Compound 4, half-maximal inhibitory concentration: > 10000 nM
Compound 4 gave a limit, no number; the forecaster's own chance of this, stated with the estimate: 50%; middle value at least 1.1-fold (0.04 log units) away from the limit.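

Compound 4 reads as a limit and not a number, so in this assay the change from (4-bromophenyl)carbonyl to (4-methylphenyl)sulfonyl on this oxygen can be given only as an at least 1.1-fold higher number from compound 3 to compound 4 (0.07 log units; that floor lies within the scatter). The steps from compound 1 and from compound 2 to compound 4 cannot be read. A sulfonyl link on this oxygen now joins the propargyl and (3-methoxyphenyl)carbonyl groups in giving no measured number, and only the (4-bromophenyl)carbonyl group gives one: the limit of > 10000 nM in this assay, at which 3 of the 4 values shown sit.

The step changes both the link and the ring substituent, so a (4-bromophenyl)sulfonyl group would be needed to separate the two. Also open, going by these compounds, is whether a chain ending in an amine or a carboxylic acid on this oxygen would give a number in this assay.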